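From 4-Chlorobenzyl to 3-Methoxybenzyl at the Assay Limit

This account rests on a few compounds, and the source may have more. Where it says the series, first, only, none or still open, it means among the compounds named here.

Of the compounds shown here, three sharing one core have been read in a physicochemical assay for solubility, using the shake flask method, in simulated intestinal fluid, measured as kinetic solubility, with a stated time of 2 h, at 25 degrees C, at pH 6.5; on this read-out higher numbers stand for higher solubility and lower numbers for lower solubility. Compound 1 (`Cc1noc(-c2nc(C)c3c(c2N)C(=O)N(Cc2ccc(-c4ccncc4)cc2)C3=O)n1`) gives < 5000 nM, which is a limit and not a number. Compound 2 (`Cc1noc(-c2nc(C)c3c(c2N)C(=O)N(Cc2ccc(-n4cccn4)cc2)C3=O)n1`) gives < 5000 nM, again a limit. Compound 3 (`Cc1noc(-c2nc(C)c3c(c2N)C(=O)N(Cc2ccc(Cl)cc2)C3=O)n1`) gives < 5000 nM, also a limit. Compound 3 therefore has no number of its own, and its place is the limit of < 5000 nM in this assay, at which 3 of the 3 values shown sit.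

Compound 4 (`COc1cccc(CN2C(=O)c3c(C)nc(-c4nc(C)no4)c(N)c3C2=O)c1`) has not yet been measured. It carries 3-methoxyphenyl in place of 4-chlorophenyl on a saturated chain carbon bound to an amide-type nitrogen in a ring.

Among the compounds with values here, two measured steps bear on this change, and both involve the same aromatic substituent region of the series. Judged by a step that the two limits leave unreadable from compound 1 to compound 3 and by a step that the two limits leave unreadable from compound 2 to compound 3, no step of readable size is on hand, and none beyond the scatter is expected, in either direction. The expected step is a step that the limit leaves unreadable from compound 3 to compound 4. Compound 4 is estimated at 2500 nM, with an expected range of 600 nM to 5000 nM.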

Compound 4, solubility: < 5000 nM
Compound 4: only a limit was reported; the forecaster's own chance of this, stated with the estimate: 85%; the middle value does not contradict the limit.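

In this assay compound 4 gives < 5000 nM as a limit and not a number. No step from compound 3 to compound 4 can therefore be read: the limit of < 5000 nM in this assay, at which 4 of the 4 values shown sit.

The compounds shown leave open the actual solubility of each, and whether the change from 4-chlorobenzyl to 3-methoxybenzyl alters it.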